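Ethyl in Place of Hydroxy on a Urea Side Ring

A few compounds are considered here, and "the series" means these few. Any claim that something is new, unique, unknown or untested is made for them only; others in the source may bear on it.

Among the measured compounds shown here, in an ADME assay for permeability, using PAMPA, at pH 7.4 (on this read-out higher numbers stand for higher permeability and lower numbers for lower permeability), compound 2 `Cc1cc(NC(=O)Nc2ccc(O)cc2)c2ccccc2n1` gives 3 10^-6 cm/s, the lowest of the three numbers measured so far. Compound 1 `Cc1cc(NC(=O)Nc2cccc(Cl)c2)c2ccccc2n1` gives 566 10^-6 cm/s in this assay, and compound 3 `Cc1cc(NC(=O)Nc2ccccc2N)c2ccccc2n1` gives 300 10^-6 cm/s. The two steps that lead away from compound 2 are both large: a 190-fold lower number from compound 1 to compound 2 (2.28 log units; beyond the scatter), and a 100-fold higher number from compound 2 to compound 3 (2.00 log units; beyond the scatter).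

Compound 4 `CCc1ccc(NC(=O)Nc2cc(C)nc3ccccc23)cc1` has not yet been measured. It differs from compound 2 by one change: ethyl in place of hydroxy on an aromatic carbon. Both measured steps bear on this change, because in a 190-fold lower number from compound 1 to compound 2 (2.28 log units; beyond the scatter) the hydroxy group is the one that enters, and in a 100-fold higher number from compound 2 to compound 3 (2.00 log units; beyond the scatter) it is the one that leaves, each time with a large shift in this assay. A step of similar size upward is therefore expected here, estimated as a 130-fold higher number from compound 2 to compound 4 (2.12 log units; beyond the scatter). Compound 4 is expected to give about 400 10^-6 cm/s in this assay, with a likely range from 150 10^-6 cm/s to 800 10^-6 cm/s.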

Compound 4, apparent permeability: 535 10^-6 cm/s
Estimate against measurement, compound 4: 1.3-fold (0.13 log units) below; measured number inside the range.
By their numbers in this assay, from the lowest: compound 2; then compounds 3, 4 and 1 (each within the scatter of the next).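

Here the group stays at one place, para to a large group, and only its identity changes, whereas the earlier steps also moved the group around the ring. In this assay this single swap of hydroxy for ethyl gives a 180-fold higher number from compound 2 to compound 4 (2.25 log units; beyond the scatter), so this place can carry a group and still show a high number, and the low number of compound 2 goes with hydroxy, not with the place being filled. The swap removes the hydrogen-bond donor and acceptor counted on hydroxy and exchanges oxygen for carbon, but no measurement here separates these changes or explains the step.

On these data alone, whether methoxy, which keeps the oxygen but lacks the hydroxy hydrogen, would fall nearer compound 2 or compound 4 stays open. So does the outcome for an amine, a carboxylic acid or a longer chain such as butyl at this same place.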